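Pyrimidine analogues: cytotoxicity of a methyl-to-hydrogen change

The compounds below may be only part of what the source reports. "The series", "measured", "known", "first", "only" and "open" are said of these compounds alone.

Measured compounds:
compound 1 `N#Cc1ccc(Nc2nc(Cc3c(F)cccc3F)cc(=O)[nH]2)cc1`: > 2500 nM
compound 2 `Cc1c(Cc2c(F)cccc2F)nc(Nc2ccc(C#N)cc2)[nH]c1=O`: > 2830 nM
compound 3 `Cc1c(N)nc(Nc2ccc(C#N)cc2)nc1C(C)c1c(F)cccc1F`: 40500 nM

Of the compounds shown here, three have been tested in an ADME assay on MT4 cells (Homo sapiens) for cytotoxicity, read by MTT assay; a higher number here means that more compound is tolerated, a lower number that less compound is tolerated. Compound 1 is reported only as a limit, > 2500 nM, in this assay. Compound 2 is likewise reported only as a limit, > 2830 nM. Going by the values given here, compound 3 is the one compound with a number, giving 40500 nM in this assay.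

Compound 2 and compound 1 differ in a single place, (hydrogen in place of methyl on an aromatic carbon). The step that the two limits leave unreadable from compound 2 to compound 1 cannot be sized because both values are limits, the limit of > 2500 nM in this assay, at which 1 of the 3 values shown sits, and (the limit of > 2830 nM in this assay, at which 1 of the 3 values shown sits).

Compound 3 has a different core from compound 2; the difference between the two cores is not broken down here.

Compound 4 `CC(c1cc(N)nc(Nc2ccc(C#N)cc2)n1)c1c(F)cccc1F` has not yet been measured. It differs from compound 3 by hydrogen in place of methyl on an aromatic carbon. This is the same kind of change as that from compound 2 to compound 1, not the same: in compound 3 the place is ortho to a large group and ortho to an amino group (1 heavy atom), whereas in compound 2 it is ortho to a group of 1 heavy atom and ortho to a group of 9 heavy atoms.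

Since the measured step of this kind gives no readable size, the expectation for compound 4 rests on compound 3 alone, whose value 40500 nM is taken as the anchor, with a step of a 1.2-fold lower number from compound 3 to compound 4 (0.06 log units; within the scatter) expected to lie within the usual scatter. Compound 4 is therefore estimated at 35000 nM in this assay, between 12000 nM and 100000 nM.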

Compound 4, half-maximal cytotoxic concentration: 46100 nM
For compound 4 the middle estimate is 1.3-fold (0.12 log units) below the measured one, within the range that was stated.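

In this assay, hydrogen in place of methyl on the aromatic carbon gives a 1.1-fold higher number from compound 3 to compound 4 (0.06 log units; within the scatter), so on the core of compound 3 this single change leaves the read-out within the scatter, at a place ortho to a large group and ortho to an amino group. This does not show that the change behaves alike on the core of compound 2, where the same kind of change leads to compound 1 and has no readable size, as both compounds stand only as limits and not as numbers. The series therefore offers one readable step on one core, which supports no rule for carrying the change from one core to another, and the surroundings of the place also differ between the two cores.

The compounds shown leave open whether a larger group at this place, such as an ethyl group, a methoxy group or a longer chain, would also stay within the scatter on the core of compound 3. They also leave open whether a chlorine atom or an amine there would do so, and how any such replacement would read on the core of compound 2.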